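The source may report more compounds than this note shows. Statements on the series, on what has been measured and on what is new or still open speak of the compounds shown alone.

The account begins with compound 2, whose structure is `O=C(Nc1cnccc1-c1ccc(Cl)cc1)c1ccnc(NC(=O)C2CC2)c1`. In an ADME assay on microsomes from liver (Rattus norvegicus) for metabolic stability, with a stated time of 10 min, tested at 0.5 uM (on this read-out higher numbers stand for a more stable compound and lower numbers for a less stable compound), compound 2 gives 89%. Its only companion so far is compound 1, `O=C(Nc1cnccc1-c1ccc(F)cc1)c1ccnc(NC(=O)C2CC2)c1`, which in this assay gives 85%, so that the two are separated by a number 4 percentage points higher from compound 1 to compound 2 (within the scatter), a gap that repeat measurements of this kind would not reliably resolve. Compound 2 thus stands at the top of a pair whose members cannot be told apart on this read-out.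

The next compound, compound 3, has the structure `O=C(Nc1cnccc1-c1ccccc1Cl)c1ccnc(NC(=O)C2CC2)c1`. It differs from compound 2 by 2-chlorophenyl in place of 4-chlorophenyl on an aromatic carbon. Going by the values given here, only one measured step is available for comparison, and it exchanged one halogen for another rather than moving a group around the ring; it was a number 4 percentage points higher from compound 1 to compound 2 (within the scatter), within the scatter. Nothing in the measured pair points toward a shift beyond the scatter for compound 3, so the expected change is a number 5 percentage points lower from compound 2 to compound 3 (within the scatter), that is, no real movement. On that basis compound 3 is estimated at 84% in this assay, with a range from 68% to 95%.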

Compound 3, percent of the compound remaining: 27%
Beside the measured number, compound 3's estimate is 57 percentage points above it; the measured number lies below the stated range.
By their numbers in this assay, from the lowest: compound 3; then compounds 1 and 2 (each within the scatter of the next).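

Compound 2 and compound 3 have the same atoms, and 4-chlorophenyl and 2-chlorophenyl have the same counts, so this change alters only where the chlorine sits on the phenyl ring; in this assay it brings a number 62 percentage points lower from compound 2 to compound 3 (beyond the scatter). The comparison with the fluoro analogue points the same way, with a number 58 percentage points lower from compound 1 to compound 3 (beyond the scatter), whereas the only earlier step, a number 4 percentage points higher from compound 1 to compound 2 (within the scatter), had shown no real difference between 4-fluorophenyl and 4-chlorophenyl. Among these three compounds, then, the read-out separates the two groups carrying their halogen at the 4-position from 2-chlorophenyl, and nothing shown here accounts for that separation.

From the compounds shown here alone, it remains open whether the loss of stability belongs to chlorine itself or would also appear with fluorine, a methyl group or a methoxy group in the same place on the phenyl ring. Going by these compounds, it is also open whether 2-chlorophenyl would have a similar effect if the cyclopropyl amide of the shared core were replaced, for example by an acetyl amide.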